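Nitro for hydrogen on the phenyl of compound 3

The source may report more compounds than this note shows. Statements on the series, on what has been measured and on what is new or still open speak of the compounds shown alone.

Of the compounds shown here, three share one core and have been measured in a functional assay on COLO 205 cells (Homo sapiens) for cytotoxicity, read by MTT assay, with a stated time of 48 h; on this read-out higher numbers stand for weaker inhibition and lower numbers for stronger inhibition. Compound 1 `O=c1ccc2cc(OCc3cc(-c4ccc5ccccc5c4)no3)ccc2o1` gives 48700 nM. Compound 2 `O=c1ccc2cc(OCc3cc(-c4cccc(Cl)c4)no3)ccc2o1` gives 32500 nM. Compound 3 `O=c1ccc2cc(OCc3cn(-c4ccccc4)nn3)ccc2o1` gives 48800 nM, the highest of the three numbers, but compound 1 and compound 2 both lie within the scatter of it, so the three values show no order.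

Compound 4 `O=c1ccc2cc(OCc3cn(-c4cccc([N+](=O)[O-])c4)nn3)ccc2o1` differs from compound 3 in one place: nitro in place of hydrogen on an aromatic carbon, read one bond further out as phenyl to 3-nitrophenyl. Among the compounds with values here, no measured pair carries this change, and the measured numbers themselves spread less than the scatter, so nothing points to a step in either direction. The step expected in this assay, a 1.1-fold lower number from compound 3 to compound 4 (0.04 log units; within the scatter), is estimated to stay within the scatter. For compound 4 the estimate is 45000 nM, with an expected range from 18000 nM to 110000 nM.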

Compound 4, half-maximal inhibitory concentration: 36600 nM
Compound 4: middle estimate off by 1.2-fold (0.09 log units), on the high side, within the range that was stated.
By their numbers in this assay, from the lowest: compounds 2, 4, 1 and 3 (each within the scatter of the next).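

In this assay, within the data shown here, nitro in place of hydrogen on the aromatic carbon gives a 1.3-fold lower number from compound 3 to compound 4 (0.12 log units; within the scatter), the first single-place pair. Phenyl to 3-nitrophenyl therefore does not separate compound 4 from compound 3 on this read-out, so this position has so far shown no response to a substituent. Nothing available gives a reason for this result.

Open, as far as these compounds go, is whether an amine or a carboxylic acid on the same aromatic carbon would separate from compound 3. Also open, from the compounds shown here alone, is whether nitro on another carbon of that ring would do so.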